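Aryl sulfonyl change on the ring nitrogen of the series

This account rests on a few compounds, and the source may have more. Where it says the series, first, only, none or still open, it means among the compounds named here.

Measured compounds:
compound 1, `COc1ccc(-c2cc(=O)c3c(OC)cc(OC)cc3[nH]2)cc1`: in a functional assay on KOPN-8 cells (Homo sapiens) for antiproliferative activity, with a stated time of 72 h (a higher number here means that more compound is needed for the effect, a lower number that less compound is needed), compound 1 gives > 31100 nM, which is a limit of the assay.
compound 2, `COc1ccc(-c2cc(=O)c3c(OC)cc(OC)cc3n2Cc2ccccc2)cc1`: compound 2 gives > 17300 nM, again a limit of the assay.
compound 3, `COc1ccc(-c2cc(=O)c3c(OC)cc(OC)cc3n2S(=O)(=O)c2ccc([N+](=O)[O-])cc2)cc1`: compound 3 gives 17300 nM.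

Going by the values given here, compound 3 thus holds the only numeric value in this set; the other two entries are limits. The step that the two limits leave unreadable from compound 1 to compound 2 cannot be sized, as both of its ends are limits (the limit of > 17300 nM in this assay, at which 1 of the 3 values shown sits, (the limit of > 31100 nM in this assay, at which 1 of the 3 values shown sits)). Among the compounds with values here, no measured step touches the aryl group on the sulfonyl sulfur, so nothing measured bears directly on the move to compound 4, `COc1ccc(-c2cc(=O)c3c(OC)cc(OC)cc3n2S(=O)(=O)c2ccc(C)c([N+](=O)[O-])c2)cc1`, in which the change is 4-methyl-3-nitrophenyl in place of 4-nitrophenyl on a sulfonyl sulfur. Within the data shown here, with no comparable step in hand, the expectation for compound 4 is a step of a 1.0-fold lower number from compound 3 to compound 4 (0.01 log units; within the scatter), that is, nothing beyond the scatter. Compound 4 is accordingly estimated at 17000 nM, with a range from 6000 nM to 50000 nM. A limit-only result for compound 4 remains a real possibility.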

Compound 4, half-maximal effective concentration: > 51700 nM
Compound 4 ended at the assay's limit (the forecaster's own chance of this, stated with the estimate: 40%); middle value at least 3.0-fold (0.48 log units) from the limit.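

In this assay, the aryl group on the sulfonyl sulfur responds to change: 4-methyl-3-nitrophenyl in place of 4-nitrophenyl gives an at least 2.9-fold higher number from compound 3 to compound 4 (0.47 log units; beyond the scatter). Compound 4 stands at a limit of the assay, and the step is therefore a floor on the size rather than a size: the limit of > 51700 nM in this assay, at which 1 of the 4 values shown sits. Going by these compounds alone, this is the first measured step at this place, and it shows that a small change in the aryl group, with the sulfonyl link kept, can move the result beyond the scatter.

Within the data shown here, the single step does not separate the added methyl from the changed place of the nitro group. Also open, as far as these compounds go, is how the series reads with a plain phenyl on the sulfonyl sulfur, or with an amine or a carboxylic acid in place of the nitro group.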